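This account rests on a few compounds, and the source may have more. Where it says the series, first, only, none or still open, it means among the compounds named here.

Measured so far:
compound 1, `C=C(c1ccc(OC)cc1NC(=O)CNC)c1ccc(OC)c2c1OC(C)(C)C=C2`: 150 nM
compound 2, `C=C(c1cc(OC)c(OC)c(OC)c1)c1ccc(OC)cc1NC(=O)CNC`: 100 nM
compound 3, `C=C(c1ccc(OC)cc1NC(=O)CNCC)c1ccc(OC)c2c1OC(C)(C)C=C2`: 970 nM

The three measured compounds were tested in a functional assay on A549 cells (Homo sapiens) for antiproliferative activity, read by MTT assay, with a stated time of 48 h; a lower number here means a stronger inhibitor, a higher number a weaker inhibitor. Compound 2 stands lowest of the three values, but its gap to compound 1 lies within the scatter, so no order between those two can be drawn. Compound 1 and compound 2 carry different cores, and the difference between the two cores is not broken down here.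

Within the core of compound 1, one change has been measured: compound 3 differs from compound 1 by methyl in place of hydrogen on a saturated chain carbon bound to an amine nitrogen, and this gave a 6.5-fold higher number from compound 1 to compound 3 (0.81 log units; beyond the scatter). Compound 3 also stands well apart from compound 2, beyond the scatter.

Compound 4, `C=C(c1cc(OC)c(OC)c(OC)c1)c1ccc(OC)cc1NC(=O)CNCC`, has not yet been measured. It differs from compound 2 by methyl in place of hydrogen on a saturated chain carbon bound to an amine nitrogen, the same change that separates compound 3 from compound 1, made here on the core of compound 2. For compound 4 the expected step in this assay is a 5.5-fold higher number from compound 2 to compound 4 (0.74 log units; beyond the scatter). This expectation rests on compound 1 and compound 3, where the same change gave a 6.5-fold higher number from compound 1 to compound 3 (0.81 log units; beyond the scatter), with some allowance for a single observation on a different core. Compound 4 is therefore estimated at 550 nM in this assay, within a range from 200 nM to 1500 nM.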

Compound 4, half-maximal inhibitory concentration: 260 nM
The estimate for compound 4 lay 2.1-fold (0.33 log units) above the measured number, and the stated range covers the measured number.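

In this assay, methylamino gave way to ethylamino on the core of compound 2, and the number rose (a 2.6-fold higher number from compound 2 to compound 4 (0.41 log units; beyond the scatter)), the same direction the change took on the core of compound 1. Set side by side, the two steps cannot be told apart in size: the same change on two cores in this assay, a 6.5-fold higher number (0.81 log units; beyond the scatter) from compound 1 to compound 3 and a 2.6-fold higher number (0.41 log units; beyond the scatter) from compound 2 to compound 4, 2.5-fold (0.40 log units) apart, within the scatter of two such steps. Going by these compounds alone, this shows that, on these two cores, the change from methyl to ethyl raised the number beyond the scatter each time and that the core made no difference that can be resolved, but it rests on only one pair of compounds per core, so it does not show that the step has one fixed size or that it would carry over to any further core.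

The compounds shown leave open how the number would respond at this place to a longer chain such as propylamino, a branched chain such as isopropylamino, a primary amine or a ring amine such as pyrrolidine. They also leave open whether the rise from methylamino to ethylamino continues along a series of chains or is confined to this single step.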